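Notes on a methyl step in the acid series

A few compounds are considered here, and "the series" means these few. Any claim that something is new, unique, unknown or untested is made for them only; others in the source may bear on it.

Measured so far:
compound 1 `Cc1cc(O)c(C(=O)O)c(C=Cc2ccc3ccccc3c2)c1` — in an ADME assay on HEK293 cells (Homo sapiens) for cytotoxicity, read by resazurin assay, with a stated time of 24 h (a higher number here means that more compound is tolerated, a lower number that less compound is tolerated), compound 1 gives 52000 nM.
compound 2 `COc1cccc(C=Cc2ccc3ccccc3c2)c1C(=O)O` — in this assay compound 2 returns only a limit, > 100000 nM.

Compound 1 and compound 2 share the same core, each carrying a carboxy group on the ring that also holds either a hydroxy or a methoxy group. Compound 1 sits inside the measurable range of this assay. Compound 2 does not: it stands at the limit of > 100000 nM in this assay, at which 1 of the 2 values shown sits, so where it truly lies is not known as a number.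

Compound 3 `COc1cc(C)cc(C=Cc2ccc3ccccc3c2)c1C(=O)O` differs from compound 2 by methyl in place of hydrogen on an aromatic carbon. Within the data shown here, no measured pair isolates this change, so its size has not been observed. Compound 1 also carries a methyl on the acid-bearing ring and is tolerated at a measurable level, which argues against a sharp drop. The step of a number no higher from compound 2 to compound 3 (the limit leaves the size open) is expected to be small or none beyond the scatter. Compound 3 is expected at 100000 nM, in a range from 40000 nM to 250000 nM, with a fair chance of again returning only a limit.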

Compound 3, half-maximal cytotoxic concentration: 119000 nM
Beside the measured number, compound 3's estimate is 1.2-fold (0.08 log units) below it; low and high end bracket the measured number.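

In this assay compound 3 gives a number and not a limit, so a methyl on this aromatic carbon, para to a carboxy group and meta to a methoxy group, still leaves a readable value on the shared core. Among these compounds, with that ring methyl held in common, methyl in place of hydrogen on an oxygen on an aromatic ring gives a 2.3-fold higher number from compound 1 to compound 3 (0.36 log units; beyond the scatter), which is the first step with a readable size, and it shows that the methoxy compound is tolerated at a higher concentration than the hydroxy compound. The step for the ring methyl itself cannot be read because compound 2 returns only a limit: the limit of > 100000 nM in this assay, at which 1 of the 3 values shown sits.

From the compounds shown here alone, the effect of the ring methyl alone therefore remains without a size, and it is open whether the step from hydroxy to methoxy would hold on a core lacking that methyl. Also open, going by these compounds, is how a longer chain such as ethyl, a chlorine atom or an amine on the same aromatic carbon would compare with methyl.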